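Swapping an acid for a cyclopropyl amide

A few compounds are considered here, and "the series" means these few. Any claim that something is new, unique, unknown or untested is made for them only; others in the source may bear on it.

Compound 1 `CC(Cc1ccc(NCc2cccc(Oc3ccccc3)c2)cc1)C(=O)O`: 70%
Compound 2 `Cc1nc(-c2ccc(C(F)(F)F)cc2)sc1CNc1ccc(CCC(=O)NC(C)C)cc1`: 84%

Both compounds were tested in a functional assay on CHO cells for agonist activity at Free fatty acid receptor 1 (Homo sapiens), read by a luciferase reporter; a lower number here means a smaller maximal response, a higher number a larger maximal response. Compound 1 gives 70%, the lower of the two numbers, while compound 2 gives 84%, which lies beyond the scatter above it. Compound 3 `CC(C)NC(=O)[C@H]1C[C@@H]1c1ccc(NCc2cccc(Oc3ccccc3)c2)cc1` has not yet been tested. It differs from compound 1 in one place: 2-(isopropylcarbamoyl)cyclopropyl in place of 2-carboxypropyl on an aromatic carbon. The expected step is a number 10 percentage points higher from compound 1 to compound 3 (within the scatter), a small rise, because compound 2 gives 84% while carrying an isopropylcarbamoyl rather than an acid. Compound 3 is therefore estimated at 80%, with a range from 62% to 95%.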

Compound 3, largest response reached (reported as percent of maximum), in percent of the reference or control that the assay uses: 62%
Beside the measured number, compound 3's estimate is 18 percentage points above it, and the stated range covers the measured number.
By their numbers in this assay, from the lowest: compounds 3 and 1 (each within the scatter of the next); then compound 2.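

In this assay, putting 2-(isopropylcarbamoyl)cyclopropyl in place of 2-carboxypropyl on this aromatic carbon, para to a large group, gives a number 8 percentage points lower from compound 1 to compound 3 (within the scatter). On this core, then, a substantial maximal response does not depend on the carboxylic acid, even though the group that enters is larger and carries a three-membered ring. Nothing measured here explains this result.

The change swaps the acid for the amide and the open chain for the ring at once, so the compounds shown cannot separate the two. A cyclopropyl ring bearing a carboxylic acid would tell them apart.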